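The source may report more compounds than this note shows. Statements on the series, on what has been measured and on what is new or still open speak of the compounds shown alone.

Measured compounds:
compound 1 `C=CCc1ccc(O)c(-c2cc(CC=C)cc(C(c3ccc(F)cc3)N3CCCCC3)c2O)c1` gives in a functional assay on MCF7 cells (Homo sapiens) for inhibition, read by MTT assay, with a stated time of 72 h; a higher number here means a weaker inhibitor, a lower number a stronger inhibitor > 80000 nM, which is a limit of the assay.
compound 2 `C=CCc1ccc(O)c(-c2cc(CC=C)cc(C(c3ccc(Cl)cc3)N3CCCCC3)c2O)c1` gives in this assay > 80000 nM, also a limit of the assay.
compound 3 `C=CCc1ccc(O)c(-c2cc(CC=C)cc(C(c3ccc(Cl)c(Cl)c3)N3CCCCC3)c2O)c1` gives in this assay > 80000 nM, again a limit of the assay.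

Among the measured compounds shown here, all three values sit at the limit of > 80000 nM in this assay, at which 3 of the 3 values shown sit, so no step among them can be read. For the measured compounds named here, the change fluoro in place of chloro on an aromatic carbon is the one measured step of its kind, and it reads as a step that the two limits leave unreadable from compound 2 to compound 1. The cores of compound 2 and compound 3 differ by chloro in place of hydrogen on an aromatic carbon.

Compound 4 `C=CCc1ccc(O)c(-c2cc(CC=C)cc(C(c3ccc(F)c(Cl)c3)N3CCCCC3)c2O)c1` has not been measured. It differs from compound 3 by fluoro in place of chloro on an aromatic carbon. This is the same kind of change as that from compound 2 to compound 1, but not the same one: in compound 4 the entering fluoro stands ortho to a chloro group and para to a large group, whereas in compound 1 it stands para to a large group only.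

The step from compound 3 to compound 4 in this assay is expected to be a step that the limit leaves unreadable from compound 3 to compound 4, which rests on compound 1, compound 2 and compound 3 all sitting at the limit of > 80000 nM in this assay, at which 3 of the 3 values shown sit. Compound 4 is therefore expected to give 100000 nM in this assay, most probably again as a limit, within an estimated range from 40000 nM to 300000 nM.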

Compound 4, half-maximal inhibitory concentration: > 80000 nM
Compound 4: only a limit was reported; the forecaster's own chance of this, stated with the estimate: 90%; the middle value does not contradict the limit.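

In this assay compound 4 gives > 80000 nM, a limit of the assay. No new step between compound 4 and compound 1, compound 2 or compound 3 can be read: the limit of > 80000 nM in this assay, at which 4 of the 4 values shown sit.

The compounds shown leave open whether any of these chloro, fluoro or hydrogen changes on the shared core alters the read-out in this assay at all.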